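A few compounds are considered here, and "the series" means these few. Any claim that something is new, unique, unknown or untested is made for them only; others in the source may bear on it.

Of the compounds shown here, two sharing one core have been read in a functional assay on NCI/ADR-RES cells (Homo sapiens) for inhibition, read by sulforhodamine B assay, with a stated time of 48 h; on this read-out lower numbers stand for higher toxicity in this test and higher numbers for lower toxicity in this test. Compound 1 is `Nc1cc(N)c2nc(-c3ccccc3)c(Oc3ccc(Cl)c(Cl)c3)nc2c1`. In this assay compound 1 gives < 100000 nM, which is a limit of the assay and not a number. Compound 2 is `COc1ccc(CNc2nc3cc(N)cc(N)c3nc2-c2ccccc2)cc1OC`. In this assay compound 2 gives < 100000 nM, again a limit rather than a number. Among the compounds with values here, compound 1 therefore stands at the limit of < 100000 nM in this assay, at which 2 of the 2 values shown sit, and no step between measured compounds can be drawn from these two values. Compound 3 is `Nc1cc(N)c2nc(-c3ccccc3)c(Sc3ccc(F)cc3)nc2c1`; it differs from compound 1 by (4-fluorophenyl)sulfanyl in place of 3,4-dichlorophenoxy on an aromatic carbon. Within the data shown here, with no measured step to rest on, the change is expected to stay within the scatter, in no particular direction. The expected step is a step that the limit leaves unreadable from compound 1 to compound 3. The estimate for compound 3 is then 60000 nM, with a range from 8000 nM to 100000 nM, and this assay is expected most likely to return only a limit again.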

Compound 3, concentration lethal to 50% of the cells: 72400 nM
The estimate for compound 3 lay 1.2-fold (0.08 log units) below the measured number; low and high end bracket the measured number.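

No step can be read between compound 1 and compound 3 in this assay, where compound 1 stands only at a limit. The compounds shown leave open whether, and by how much, (4-fluorophenyl)sulfanyl in place of 3,4-dichlorophenoxy on an aromatic carbon shifts the value in this assay.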